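The source may hold more compounds than are shown below. What is called first, only, known or untested is meant among the compounds shown, and "the series" means these compounds.

Compound 1 `CC(C)CC(=O)OC1C(C(O)CO)OC2OC(C)(C)OC21`: 1000000 nM
Compound 2 `CC(=O)OC1C(C(O)CO)OC2OC(C)(C)OC21`: 3800000 nM

In a functional assay on K562 cells (Homo sapiens) for inhibition (a lower number here means a stronger inhibitor, a higher number a weaker inhibitor), compound 1 holds the lower of the two numbers, at 1000000 nM, and compound 2 is its nearest neighbour. Compound 3 `CC1(C)OC2OC(C(O)CO)C(OC(=O)C3CCCC3)C2O1` differs from compound 1 by cyclopentyl in place of isobutyl on a carbonyl carbon, with cyclopentyl in place of isobutyl on a carbonyl carbon. Within the data shown here, the one measured step that bears on this is a 3.8-fold higher number from compound 1 to compound 2 (0.58 log units; beyond the scatter), with hydrogen in place of isopropyl on a saturated chain carbon bound to a carbonyl carbon. Compound 3 keeps a carbon group there, so in this assay a smaller step is expected, probably within the scatter and with no firm direction. The estimated value for compound 3 is 900000 nM (350000 nM to 2500000 nM). This estimate means an expected 1.1-fold lower number from compound 1 to compound 3 (0.05 log units; within the scatter).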

Compound 3, half-maximal inhibitory concentration: 2500000 nM
The estimate for compound 3 lay 2.8-fold (0.44 log units) below the measured number; the range from low to high includes it.
By their numbers in this assay, from the lowest: compound 1; then compounds 3 and 2 (each within the scatter of the next).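

In this assay, cyclopentyl in place of isobutyl on the carbonyl carbon gives a 2.5-fold higher number from compound 1 to compound 3 (0.40 log units; beyond the scatter), so keeping a carbon group at this position does not by itself preserve the number of compound 1. Cyclopentyl in place of methyl gives a 1.5-fold lower number from compound 2 to compound 3 (0.18 log units; within the scatter), so here the ring offers no measurable gain over methyl. No evidence accounts for this difference between isobutyl and cyclopentyl. The compounds shown leave open whether a longer chain, a phenyl ring or an amine on this carbonyl carbon would give a lower number than isobutyl.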